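A few compounds are considered here, and "the series" means these few. Any claim that something is new, unique, unknown or untested is made for them only; others in the source may bear on it.

Within the data shown here, compound 2 `COc1cc2c(cc1OC)C(=O)/C(=C/c1cc(C)cc(C)c1)CC2` holds the only plain number in a functional assay on Jurkat cells (Homo sapiens) for antiproliferative activity, read by MTT assay; a higher number here means a weaker inhibitor, a lower number a stronger inhibitor: compound 2 gives 4000 nM. For compound 1 `COc1ccc(/C=C2\CCc3cc(OC)c(OC)cc3C2=O)cc1` this assay reports only a limit, > 50000 nM, as the evidence notes (the limit of > 50000 nM in this assay, at which 1 of the 2 values shown sits). Among the measured compounds shown here, the single measured step, an at least 12-fold lower number from compound 1 to compound 2 (1.09 log units; beyond the scatter), shows that swapping the aromatic group on the double-bonded chain carbon can move the number a long way. Compound 3 `COc1cc2c(cc1OC)C(=O)/C(=C/c1cc(Cl)cc(Cl)c1)CC2` makes a smaller change at that same place: 3,5-dichlorophenyl in place of 3,5-dimethylphenyl on a double-bonded chain carbon bound to a double-bonded ring carbon. For the measured compounds named here, the same arrangement of two substituents on the phenyl ring is kept and only the two methyl groups become chlorines, so the one measured step is a loose guide at best; a shift of about the size of the usual scatter, in either direction, is the expectation, with the step from compound 2 to compound 3 estimated as a 1.3-fold lower number from compound 2 to compound 3 (0.12 log units; within the scatter). On that basis compound 3 is estimated at 3000 nM, with a likely range from 800 nM to 12000 nM.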

Compound 3, half-maximal inhibitory concentration: 7000 nM
Beside the measured number, compound 3's estimate is 2.3-fold (0.37 log units) below it; low and high end bracket the measured number.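

Exchanging the two methyl groups of 3,5-dimethylphenyl for the two chlorines of 3,5-dichlorophenyl gives a 1.8-fold higher number from compound 2 to compound 3 (0.24 log units; within the scatter), so in this assay compound 2 and compound 3 cannot be told apart, even though the atoms on the phenyl ring have changed. Replacing 4-methoxyphenyl with 3,5-dichlorophenyl also gives an at least 7.1-fold lower number from compound 1 to compound 3 (0.85 log units; beyond the scatter), which shows that the step first seen with compound 2 is not confined to methyl groups. The figure for compound 1 is a limit, not a number: the limit of > 50000 nM in this assay, at which 1 of the 3 values shown sits.

The compounds shown leave open what an unsubstituted phenyl group would give at this place, and so whether losing 4-methoxyphenyl or gaining the two substituents matters more. They also leave open how 3,5-dimethoxyphenyl or 3,5-diaminophenyl would behave there.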